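Trimming the Alkyne Chain and Cytotoxicity in HEL Cells

A few compounds are considered here, and "the series" means these few. Any claim that something is new, unique, unknown or untested is made for them only; others in the source may bear on it.

In an ADME assay on HEL cells (Homo sapiens) for cytotoxicity, read by cell counting, with a stated time of 3 days (on this read-out lower numbers stand for higher toxicity in this test and higher numbers for lower toxicity in this test), compound 2 `CC(=O)OC[C@H]1O[C@@H](n2cc3c(C#CCCN4C(=O)c5ccccc5C4=O)c(-c4ccc(C)cc4)oc3nc2=O)C[C@@H]1OC(C)=O` gives 100000 nM. Compound 3 `CCCCCc1ccc(-c2oc3nc(=O)n([C@H]4C[C@H](OC(C)=O)[C@@H](COC(C)=O)O4)cc3c2C#CCCO)cc1` gives 100000 nM in this assay, level with compound 2 at the digits shown, and these two share the highest number of the three. Compound 1 `CCCCCc1ccc(C#Cc2c(-c3ccc(C)cc3)oc3nc(=O)n([C@H]4C[C@H](OC(C)=O)[C@@H](COC(C)=O)O4)cc23)cc1` gives 20000 nM in this assay, a lower number than compound 2 that lies beyond the scatter. Compound 4 `COCC#Cc1c(-c2ccc(C)cc2)oc2nc(=O)n([C@H]3C[C@H](OC(C)=O)[C@@H](COC(C)=O)O3)cc12` has not yet been measured. It differs from compound 2 by a group of 2 heavy atoms (1 carbon, 1 oxygen; no ring) in place of a group of 12 heavy atoms (9 carbon, 1 nitrogen, 2 oxygen; one five-membered non-aromatic ring with 1 hetero atom, one six-membered aromatic ring of carbon only), on a saturated chain carbon bound to a triple-bonded carbon. Among the measured compounds shown here, no step between measured compounds is known. The expected step of no change at the digits printed from compound 2 to compound 4 (within the scatter) is none beyond the scatter. Compound 4 is expected to give about 100000 nM, with a range from 30000 nM to 200000 nM, in this assay.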

Compound 4, minimum cytotoxic concentration: > 100000 nM
Compound 4 was reported as a limit; the forecaster's own chance of this, stated with the estimate: 50%; the middle value lies on the limit itself.
By their numbers in this assay, from the lowest: compound 1; then compounds 2 and 3 (each within the scatter of the next).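

Compound 4 gives > 100000 nM in this assay as a limit of the assay and not a number. Methoxy in place of the group of 12 heavy atoms gives a number no lower from compound 2 to compound 4 (the limit leaves the size open) on the saturated chain carbon bound to a triple-bonded carbon, so the large ring-bearing group is not needed for the high number. Methoxymethyl in place of 4-pentylphenyl on a triple-bonded carbon gives an at least 5.0-fold higher number from compound 1 to compound 4 (0.69 log units; beyond the scatter) and is the first measured step at this position that clears the scatter. As far as these compounds go, how far above the limit compound 4 lies stays open. So does whether an amine or a carboxylic acid on that chain carbon would keep the number there.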